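The source may report more compounds than this note shows. Statements on the series, on what has been measured and on what is new or still open speak of the compounds shown alone.

Compound 1 `O=C(CSc1nc(Nc2ccccc2)c2ccccc2n1)Nc1ccccc1F` gives 9350 nM in a functional assay on NCI-H1975 cells (Homo sapiens) for inhibition, read by MTT assay, with a stated time of 72 h; a lower number here means a stronger inhibitor, a higher number a weaker inhibitor. Compound 2 `COc1cccc(NC(=O)CSc2nc(Nc3ccccc3)c3ccccc3n2)c1` gives 19400 nM in this assay. Compound 3 `O=C(CSc1nc(Nc2ccccc2)c2ccccc2n1)Nc1ccc(Cl)cc1` gives 8040 nM in this assay.

Of these three, compound 3 has the lowest number, though its gap to compound 1 is within the scatter, so the two cannot be ranked; only compound 2 stands clearly apart, as the step of a 2.4-fold lower number from compound 2 to compound 3 (0.38 log units; beyond the scatter) shows. The step of a 1.2-fold lower number from compound 1 to compound 3 (0.07 log units; within the scatter) shows that exchanging one halogen-bearing phenyl on the amide-type nitrogen for another left the number essentially where it was.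

Compound 4 `O=C(CSc1nc(Nc2ccccc2)c2ccccc2n1)Nc1ccc(F)c(Cl)c1` has not yet been measured in this assay. It differs from compound 3 in one place: 3-chloro-4-fluorophenyl in place of 4-chlorophenyl on an amide-type nitrogen. The two measured steps that bear on this are a 1.2-fold lower number from compound 1 to compound 3 (0.07 log units; within the scatter) and a 2.4-fold lower number from compound 2 to compound 3 (0.38 log units; beyond the scatter); the change from compound 3 to compound 4 keeps the chlorine and only adds a fluorine, which is closer in kind to the small first step than to the second. No step beyond the scatter is therefore expected in this assay. Compound 4 is estimated at 7500 nM, in a range from 3500 nM to 16000 nM, which means an expected step of a 1.1-fold lower number from compound 3 to compound 4 (0.03 log units; within the scatter).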

Compound 4, half-maximal inhibitory concentration: 9390 nM
Compound 4: middle estimate off by 1.3-fold (0.10 log units), on the low side; low and high end bracket the measured number.
By their numbers in this assay, from the lowest: compounds 3, 1 and 4 (each within the scatter of the next); then compound 2.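

The swap from 4-chlorophenyl to 3-chloro-4-fluorophenyl on the amide-type nitrogen does more than add a fluorine, since the group names also put the chlorine at a different ring position, yet in this assay it gives only a 1.2-fold higher number from compound 3 to compound 4 (0.07 log units; within the scatter). With a 1.0-fold higher number from compound 1 to compound 4 (0.00 log units; within the scatter) as well, compounds 1, 3 and 4 cannot be told apart, so three different halogen-bearing phenyl groups at this position read alike, while a 2.1-fold lower number from compound 2 to compound 4 (0.32 log units; beyond the scatter) leaves compound 2, with its 3-methoxyphenyl, as the one exception. No measurement at hand explains these numbers.

Still open, on these data alone, is whether an amine or a carboxylic acid on this phenyl, or a plain alkyl chain in its place, would move the number clearly away from this level. Nor do these compounds show what a change elsewhere on the shared core would do.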